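Methoxy in Place of Dimethylamino: Expected Cytotoxicity of Compound 3

This account rests on a few compounds, and the source may have more. Where it says the series, first, only, none or still open, it means among the compounds named here.

Going by the values given here, compound 1 `Cc1c(/N=C/c2ccc(N(C)C)cc2)c(=O)n(-c2ccccc2)n1C` is one of two compounds measured in a functional assay on DLD-1 cells (Homo sapiens) for cytotoxicity, read by MTT assay, with a stated time of 72 h (a higher number here means a weaker inhibitor, a lower number a stronger inhibitor), where compound 1 gives 871000000 nM, the higher of the two numbers. Compound 2 `CCOc1cccc(/C=N/c2c(C)n(C)n(-c3ccccc3)c2=O)c1` gives 724000000 nM in this assay, a gap to compound 1 that lies within the scatter. Compound 3 `COc1ccc(/C=N/c2c(C)n(C)n(-c3ccccc3)c2=O)cc1` differs from compound 1 by methoxy in place of dimethylamino on an aromatic carbon. Among the compounds with values here, no measured pair shows this change, so no step beyond the scatter is expected in this assay in either direction. Compound 3 is estimated at 800000000 nM, with a range from 300000000 nM to 2000000000 nM. This corresponds to an expected step of a 1.1-fold lower number from compound 1 to compound 3 (0.04 log units; within the scatter).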

Compound 3, half-maximal inhibitory concentration: 977000000 nM
For compound 3 the middle estimate is 1.2-fold (0.09 log units) below the measured one, within the range that was stated.
By their numbers in this assay, from the lowest: compounds 2, 1 and 3 (each within the scatter of the next).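

Compound 1 and compound 3 form the first measured pair differing in one place, and in this assay methoxy in place of dimethylamino, on an aromatic carbon para to a large group, gives a 1.1-fold higher number from compound 1 to compound 3 (0.05 log units; within the scatter) as the step. At this position, then, the two groups cannot be told apart in this read-out. No measured evidence bears on why this is so.

As far as these compounds go, whether a carboxylic acid or a longer chain at this position would give a step beyond the scatter remains open. So does whether any other change to the shared core would.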